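The source may report more compounds than this note shows. Statements on the series, on what has been measured and on what is new or still open speak of the compounds shown alone.

Of the compounds shown here, two have so far been tested in an ADME assay on HepG2 cells (Homo sapiens) for cytotoxicity, read by CellTiter-Glo and resazurin assay, with a stated time of 72 h; on this read-out lower numbers stand for an effect already at smaller amounts and higher numbers for an effect only at larger amounts of compound. Compound 1 `CC(C)N(Cc1cccc(OCCCCCC(=O)O)c1)C(=O)c1ccccc1` is the smaller of the pair. In this assay compound 1 returns only a limit, > 26000 nM, which is the limit of > 26000 nM in this assay, at which 1 of the 2 values shown sits. Compound 2 `CCOc1cccc(-c2ccc(C(=O)N(Cc3cccc(OCCCCCC(=O)O)c3)C(C)C)cc2)c1` carries a 3-ethoxyphenyl in place of hydrogen on an aromatic carbon of the shared core. In this assay compound 2 likewise returns only a limit, > 20800 nM, which is the limit of > 20800 nM in this assay, at which 1 of the 2 values shown sits. The step that the two limits leave unreadable from compound 1 to compound 2 therefore cannot be read as a number: both of its ends are limits. Compound 3 `CC(C)N(Cc1cccc(OCCCCCC(=O)O)c1)C(=O)c1ccc(-c2cccc(O)c2)cc1` differs from compound 2 in a single place: hydrogen in place of ethyl on an oxygen on an aromatic ring, so that ethoxy becomes hydroxy and 3-ethoxyphenyl becomes 3-hydroxyphenyl. Among the compounds with values here, no measured step bears directly on this change, and the one step that has been measured, the addition of the whole 3-ethoxyphenyl, gave no readable size. The step expected here, a step that the limit leaves unreadable from compound 2 to compound 3, is of no size beyond the scatter. Compound 3 is therefore estimated to reach only the limit again, with an expected value in this assay of 30000 nM and a range from 12000 nM to 80000 nM.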

Compound 3, half-maximal effective concentration: > 26000 nM
Compound 3: no number, only a limit; the forecaster's own chance of this, stated with the estimate: 75%; the middle value is on the limit's open side.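

Within the data shown here, compound 1, compound 2 and compound 3 all return only limits in this assay, so no step among them can be read as a size. The compounds shown leave open at what concentration any of the three would reach a half-maximal effect, and whether hydroxy in place of ethoxy changes that concentration at all.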